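The compounds below may be only part of what the source reports. "The series", "measured", "known", "first", "only" and "open" are said of these compounds alone.

Three compounds have been measured in a functional assay, read by spectrophotometry, with a stated time of 30 min, tested at 100 ug/mL; a higher number here means a stronger effect of the compound at the concentration tested, a lower number a weaker effect:

Compound 1 `CCN1CCN(CC(=O)Nc2nc3ccccc3[nH]2)CC1`: 45.7%
Compound 2 `O=C(CN1CCN(c2ccccn2)CC1)Nc1nc2ccccc2[nH]1`: 57.3%
Compound 3 `COc1ccc(N2CCN(CC(=O)Nc3nc4ccccc4[nH]3)CC2)cc1`: 38.9%

Compound 2 stands highest of the three. Its nearest neighbour is compound 1, and the gap a number 11.6 percentage points higher from compound 1 to compound 2 (beyond the scatter) lies beyond the scatter; the gap to compound 3, a number 18.4 percentage points lower from compound 2 to compound 3 (beyond the scatter), is larger still. Between compound 1 and compound 3 the change a number 6.8 percentage points lower from compound 1 to compound 3 (within the scatter) lies within the scatter, so those two cannot be ordered.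

Compound 4 `COc1ccccc1N1CCN(CC(=O)Nc2nc3ccccc3[nH]2)CC1` has not yet been measured. It differs from compound 2 in one place: 2-methoxyphenyl in place of pyridin-2-yl on an amine nitrogen in a ring. For the measured compounds named here, the step that bears most directly on this is the one from compound 2 to compound 3, where 4-methoxyphenyl replaced pyridin-2-yl at the same ring nitrogen and this assay fell by a number 18.4 percentage points lower from compound 2 to compound 3 (beyond the scatter). Compound 4 carries a 2-methoxyphenyl group instead, so the data give a close but not identical precedent. On that precedent a drop of a modest size, beyond the scatter, is expected, with the estimated step being a number 15.3 percentage points lower from compound 2 to compound 4 (beyond the scatter). Compound 4 is therefore estimated to give 42% in this assay, with a likely range from 28% to 56%.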

Compound 4, a percentage reported as activity, at one concentration (the size of the read-out at that concentration, not a potency): 43.2%
Compound 4: middle estimate off by 1.2 percentage points, on the low side; the range from low to high includes it.
By their numbers in this assay, from the lowest: compounds 3, 4 and 1 (each within the scatter of the next); then compound 2.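

Swapping one methoxyphenyl group for the other at this ring nitrogen gives no readable change in this assay (a number 4.3 percentage points higher from compound 3 to compound 4 (within the scatter)), so 2-methoxyphenyl and 4-methoxyphenyl cannot be told apart here. The earlier drop seen on leaving pyridin-2-yl now has a second example (a number 14.1 percentage points lower from compound 2 to compound 4 (beyond the scatter)), and compound 2 stands beyond the scatter from each of the other three compounds, with either methoxyphenyl group or ethyl in that place. The comparison with ethyl (a number 2.5 percentage points lower from compound 1 to compound 4 (within the scatter)) also shows that 2-methoxyphenyl cannot be separated from this much smaller group, so among compounds 1, 3 and 4 the choice of group at this nitrogen has no readable effect on the result.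

Going by these compounds, it remains open whether the nitrogen within the pyridin-2-yl ring matters, which a plain phenyl group, pyridin-4-yl or pyrimidin-2-yl at the same ring nitrogen would help to test. Nothing available here explains why pyridin-2-yl gives the highest number.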